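Removing a Chloro Group from an Antiproliferative Hydrazone

A few compounds are considered here, and "the series" means these few. Any claim that something is new, unique, unknown or untested is made for them only; others in the source may bear on it.

Among the measured compounds shown here, compound 2 `COc1ccc(OC)c(/C=C/C(=O)N/N=C/c2ccc(Cl)cc2)c1` stands lowest of the two numbers measured so far in a functional assay on 786-0 cells (Homo sapiens) for antiproliferative activity, read by sulforhodamine B assay, with a stated time of 48 h (on this read-out higher numbers stand for weaker inhibition of growth and lower numbers for stronger inhibition of growth), where compound 2 gives 326 nM. Compound 1 `COc1ccc(OC)c(/C=C/c2nnc(Nc3ccc(Cl)cc3)o2)c1` gives 2670 nM in this assay, a gap beyond the scatter. Compound 3 `COc1ccc(OC)c(/C=C/C(=O)N/N=C/c2ccccc2)c1` differs from compound 2 only by hydrogen in place of chloro on an aromatic carbon. For the measured compounds named here, no step of this kind has been measured here, so a modest loss of potency is expected, a step that may reach just beyond the scatter. Compound 3 is estimated at 700 nM in this assay, within 250 nM to 2500 nM, an expected step of a 2.1-fold higher number from compound 2 to compound 3 (0.33 log units; beyond the scatter).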

Compound 3, concentration for 50% growth inhibition: 7000 nM
Compound 3: the middle estimate sits 10-fold (1.00 log units) below what was measured, outside the stated range (above it).
By their numbers in this assay, from the lowest: compound 2; then compound 1; then compound 3.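

In this assay, the step of a 21-fold higher number from compound 2 to compound 3 (1.33 log units; beyond the scatter) shows that the chloro group matters a great deal here: the 4-chlorophenyl to phenyl change costs much of the growth inhibition. Losing one heavy atom at this place, para to a large group, is enough to turn a strong inhibitor into a far weaker one. No measurement available here explains the size of this loss. Open questions are whether fluoro or bromo at this place would keep the potency of compound 2, and whether chloro matters equally on the core of compound 1.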